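Notes on a bile acid receptor series: compound 1 to 3

A few compounds are considered here, and "the series" means these few. Any claim that something is new, unique, unknown or untested is made for them only; others in the source may bear on it.

compound 1 `Cc1ccccc1-n1nc(C)c2c1NC(=O)[C@H](C)S[C@@H]2c1ccc(-c2ccoc2)cc1`: 3500 nM
compound 2 `COc1cccc(-c2ccc([C@H]3S[C@@H](C)C(=O)Nc4c3c(C)nn4-c3ccccc3C)cc2)c1`: 1800 nM

Among the measured compounds shown here, in an assay on isolated protein for agonist activity at Bile acid receptor (Homo sapiens), read by AlphaScreen, with a stated time of 30 min (a lower number here means that less compound is needed, a higher number that more compound is needed for the effect), compound 1 gives 3500 nM, the higher of the two numbers so far. Compound 2 gives 1800 nM, and the step of a 1.9-fold lower number from compound 1 to compound 2 (0.29 log units; within the scatter) lies within the scatter. Compound 3 `Cc1ccccc1-n1nc(C)c2c1NC(=O)[C@H](C)S[C@@H]2c1ccc(Oc2ccccc2C(=O)O)cc1` differs from compound 1 by 2-carboxyphenoxy in place of furan-3-yl on an aromatic carbon. For the measured compounds named here, the only measured step bearing on it also swaps the furan-3-yl for a six-membered aromatic group, and a 1.9-fold lower number from compound 1 to compound 2 (0.29 log units; within the scatter) stayed within the scatter; no measured compound carries a carboxylic acid. The expectation is therefore a step of a 1.4-fold lower number from compound 1 to compound 3 (0.15 log units; within the scatter), within or near the scatter. Compound 3 is estimated at 2500 nM, range 800 nM to 8000 nM.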

Compound 3, half-maximal effective concentration: "not active" (no number reported)
For compound 3 the study gives words and no number, so the estimate cannot be set against anything.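

Among the compounds shown here, compound 3 is reported as "not active" with no number, so no step from compound 1 or compound 2 to compound 3 can be read, and no evidence bears on this result. In this assay the compounds shown leave open how 2-carboxyphenoxy compares numerically with furan-3-yl at this place.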